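Methyl on the imidazole of a poorly soluble analogue

The source may hold more compounds than are shown below. What is called first, only, known or untested is meant among the compounds shown, and "the series" means these compounds.

Compound 1 `CC(C)(C)c1ncc2c(N)c(C#N)c(N)nc2n1` and compound 2 `Cc1nc(C(C)(C)C)nc2nc(N)c(C#N)c(N)c12` share one core. In a physicochemical assay for solubility, in phosphate buffer, with a stated time of 18 h (on this read-out higher numbers stand for higher solubility and lower numbers for lower solubility), compound 1 gives 37200 nM. Compound 2 gives 37000 nM in this assay. The change between them is methyl in place of hydrogen on an aromatic carbon and the step it made is a 1.0-fold lower number from compound 1 to compound 2 (0.00 log units; within the scatter). Compound 3 `CC(C)(C)c1nc(-c2ncc[nH]2)c2c(N)c(C#N)c(N)nc2n1` carries a different group at that carbon: the difference is 1H-imidazol-2-yl in place of hydrogen on an aromatic carbon, with a step of an at least 37-fold lower number from compound 1 to compound 3 (1.57 log units; beyond the scatter). For compound 3, this assay gives only a limit, < 1000 nM (the limit of < 1000 nM in this assay, at which 1 of the 3 values shown sits). Compound 4 `Cc1c[nH]c(-c2nc(C(C)(C)C)nc3nc(N)c(C#N)c(N)c23)n1` differs from compound 3 by methyl in place of hydrogen on an aromatic carbon. This is the same kind of change as from compound 1 to compound 2, but here the methyl enters on the aromatic carbon of a five-membered aromatic ring with 2 nitrogen, not on the six-membered aromatic ring of the fused core. Because the earlier methyl step was a 1.0-fold lower number from compound 1 to compound 2 (0.00 log units; within the scatter), the step from compound 3 to compound 4 is expected to be a step that the limit leaves unreadable from compound 3 to compound 4. Compound 4 is thus expected to show about 700 nM, quite possibly again reported only as a limit.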

Compound 4, solubility: 5000 nM
Beside the measured number, compound 4's estimate is 7.1-fold (0.85 log units) below it; measured number above the stated range.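

In this assay the methyl step on the shared core is a 1.0-fold lower number from compound 1 to compound 2 (0.00 log units; within the scatter) and on the five-membered aromatic ring with 2 nitrogen it is an at least 5.0-fold higher number from compound 3 to compound 4 (0.69 log units; beyond the scatter), so the same change does not give the same step in both places. As far as these compounds go, the full size of the second step stays unknown, since compound 3 stands only as a limit: the limit of < 1000 nM in this assay, at which 1 of the 4 values shown sits. The steps of a 7.4-fold lower number from compound 1 to compound 4 (0.87 log units; beyond the scatter) and a 7.4-fold lower number from compound 2 to compound 4 (0.87 log units; beyond the scatter) show that the methyl does not bring compound 4 level with the compounds lacking the 1H-imidazol-2-yl group.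

The compounds shown leave open whether an ethyl group, an amine or a carboxylic acid on that ring would give a different number.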